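An Aromatic Swap on a Scaffold Without Measured Activity

This account rests on a few compounds, and the source may have more. Where it says the series, first, only, none or still open, it means among the compounds named here.

Measured compounds:
compound 1 `O=C1OCC[C@@H]1NC(=S)SCCOc1ccccc1Cc1ccccc1` — > 64000 nM
compound 2 `O=C(CNc1ccccc1F)N[C@H]1CCOC1=O` — > 64000 nM

In a functional assay on PC-3 cells (Homo sapiens) for antiproliferative activity, read by MTT assay, with a stated time of 72 h (on this read-out higher numbers stand for weaker inhibition and lower numbers for stronger inhibition), compound 1 gives > 64000 nM, which is a limit of the assay and not a number. Compound 2 gives > 64000 nM in this assay, again a limit rather than a number. Both results therefore sit at the limit of > 64000 nM in this assay, at which 2 of the 2 values shown sit, so compound 1 cannot be placed above or below compound 2; all that is known of compound 1 is that it did not reach measurable inhibition within the tested range.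

Compound 3 `CCOc1ccccc1OCCSC(=S)N[C@H]1CCOC1=O` keeps the shared core of compound 1 and changes one position on the aromatic ring: ethoxy in place of benzyl on an aromatic carbon. Within the data shown here, no step between two measured compounds exists to guide this change, and nothing in the two limits shows a direction. Compound 3 is therefore expected to remain at the limit, with the step of a number no higher from compound 1 to compound 3 (the limit leaves the size open) estimated as none beyond the scatter. The estimate for compound 3 in this assay is 64000 nM, within a range from 20000 nM to 200000 nM.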

Compound 3, half-maximal inhibitory concentration: 24100 nM
Beside the measured number, compound 3's estimate is 2.7-fold (0.42 log units) above it, and the stated range covers the measured number.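

In this assay, placing ethoxy in place of benzyl on an aromatic carbon, ortho to a large group, gives an at least 2.6-fold lower number from compound 1 to compound 3 (0.42 log units; beyond the scatter). This is the first change shown that moves the read-out beyond the scatter, and it shows that this position on the aromatic ring can respond to a change of group, although the inhibition remains weak in absolute terms. Only compound 3 gives a number on this read-out, and the other values shown are limits of the assay: the limit of > 64000 nM in this assay, at which 2 of the 3 values shown sit.

Among these compounds, the step gives only a lower bound on the size of the change, and the single swap does not separate its parts: an aromatic ring leaves, the heavy-atom count falls, and a hydrogen-bond acceptor enters. Going by these compounds, whether the oxygen of ethoxy matters, or simply the loss of benzyl, remains open, as does what a methoxy group, a longer propoxy chain, an amine or a carboxylic acid at the same aromatic carbon would do to the read-out.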